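The source may report more compounds than this note shows. Statements on the series, on what has been measured and on what is new or still open speak of the compounds shown alone.

Measured in an assay on CHO cells for displacement of a labelled ligand from Substance-P receptor (Homo sapiens), with a stated time of 90 min; on this read-out lower numbers stand for stronger inhibition and higher numbers for weaker inhibition:

Compound 1 `Cc1nc(Cl)cc(-c2ccccc2)c1C(=O)NCc1cc(C(F)(F)F)cc(C(F)(F)F)c1`: 270 nM
Compound 2 `Cc1nc(Cl)cc(-c2ccccc2)c1C(=O)N(C)Cc1cc(C(F)(F)F)cc(C(F)(F)F)c1`: 91 nM
Compound 3 `Cc1c(C(=O)NCc2cc(C(F)(F)F)cc(C(F)(F)F)c2)c(-c2ccccc2)cc2nnnn12`: 279 nM

Compound 1 and compound 2 share one core and differ by methyl in place of hydrogen on an amide-type nitrogen; this change gave a 3.0-fold lower number from compound 1 to compound 2 (0.47 log units; beyond the scatter). Compound 3 has a different core; the difference between the two cores is not broken down here, and the values of compound 1 and compound 3 lie within the scatter of each other. Compound 4 `Cc1c(C(=O)N(C)Cc2cc(C(F)(F)F)cc(C(F)(F)F)c2)c(-c2ccccc2)cc2nnnn12` differs from compound 3 by methyl in place of hydrogen on an amide-type nitrogen, the same change at the same kind of place. Because the same change gave a 3.0-fold lower number from compound 1 to compound 2 (0.47 log units; beyond the scatter), a step of similar size is expected from compound 3 to compound 4, namely a 2.9-fold lower number from compound 3 to compound 4 (0.47 log units; beyond the scatter). On that basis compound 4 is estimated at 95 nM in this assay, likely between 45 nM and 200 nM.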

Compound 4, half-maximal inhibitory concentration: 57 nM
Estimate against measurement, compound 4: 1.7-fold (0.22 log units) above; the range from low to high includes it.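

In this assay, methyl in place of hydrogen on the amide-type nitrogen gave a 4.9-fold lower number from compound 3 to compound 4 (0.69 log units; beyond the scatter). The step on this core agrees with the earlier one within the scatter, so the change carried over from the core of compound 1 to the core of compound 3 with much the same size: the same change on two cores in this assay, a 3.0-fold lower number (0.47 log units; beyond the scatter) from compound 1 to compound 2 and a 4.9-fold lower number (0.69 log units; beyond the scatter) from compound 3 to compound 4, 1.6-fold (0.22 log units) apart, within the scatter of two such steps. This is one pair on each of two cores in a single assay; it does not show that the step would hold on other cores, and it does not explain why the methyl has this effect.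

The compounds shown leave open whether ethyl or a longer chain on that nitrogen would give a step of similar size. They also leave open what an amine at the end of such a chain would do.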